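The source may hold more compounds than are shown below. What is called first, only, known or untested is meant among the compounds shown, and "the series" means these compounds.

Compounds measured in an assay on isolated protein for inhibition of Alpha glucosidase (Homo sapiens), with stated times of 5 min and 15 min, tested at 50 uM; a lower number here means less inhibition, a higher number more inhibition at the concentration tested (going by the name of the read-out):
- compound 1, `Cc1ccc(/C=C2\CCC/C(=C\c3ccccc3)C2=O)cc1`, gives 34.1%
- compound 2, `O=C(/C=C(O)/C=C/c1ccco1)c1cc(O)ccc1O`, gives 98.4%

Of the two numbers, compound 1 stands lowest; compound 2 sits well above it, with a gap beyond the usual scatter. The next compound, compound 3, `O=C1/C(=C/c2ccccc2)CCC/C1=C\c1cccc(F)c1`, differs from compound 1 by 3-fluorophenyl in place of 4-methylphenyl on a double-bonded chain carbon bound to a double-bonded ring carbon. Among the compounds with values here, no step between measured compounds that differ in one place is at hand, so the size of this change has to be judged from the compounds themselves. Because compound 1 gives 34.1%, the step of a number 0.9 percentage points higher from compound 1 to compound 3 (within the scatter) is expected to be small, not beyond the scatter in either direction. Compound 3 is estimated at 35%, between 15% and 55%.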

Compound 3, a percentage reported as inhibition, at one concentration (the size of the read-out at that concentration, not a potency): 39.8%
Estimate against measurement, compound 3: 4.8 percentage points below; low and high end bracket the measured number.
By their numbers in this assay, from the lowest: compounds 1 and 3 (each within the scatter of the next); then compound 2.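

In this assay, within the data shown here, putting 3-fluorophenyl in place of 4-methylphenyl on a double-bonded chain carbon bound to a double-bonded ring carbon gives a number 5.7 percentage points higher from compound 1 to compound 3 (within the scatter) and provides the first comparison of compounds that differ in one place. At this position, this exchange therefore shows no difference that can be told from the scatter. Nothing measured here bears on the reason for this. On these data alone, whether an amine or a carboxylic acid at this position would give a different number remains open, as does the effect of the same exchange on the other double-bonded chain carbon.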